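Swapping Methyl for Fluoro on a Sulfur-Containing Ring

The compounds below may be only part of what the source reports. "The series", "measured", "known", "first", "only" and "open" are said of these compounds alone.

Measured so far:
- compound 1, `Sc1nccn1Cc1ccsc1`: 5300 nM
- compound 2, `Cc1ccc(Cn2ccnc2S)s1`: 6000 nM

Both compounds were tested in an assay on isolated protein for inhibition of Dopamine beta-hydroxylase (Bos taurus); on this read-out lower numbers stand for stronger inhibition and higher numbers for weaker inhibition. In this assay compound 1 gives 5300 nM, and compound 2 gives 6000 nM. Compound 2 has the higher of the two numbers, but the gap to compound 1 is within the usual scatter of repeated measurements, so the two compounds cannot be told apart on these data.

Compound 3, `Fc1ccc(Cn2ccnc2S)s1`, is the next compound to be tested in this assay. It differs from compound 2 in one place: fluoro in place of methyl on an aromatic carbon. Among the compounds with values here, no step between two measured compounds matches this change, so there is no direct guide to its effect. Within the data shown here, with only one single-atom swap at the edge of the shared core, the expectation is a step from compound 2 to compound 3 of about no change at the digits printed from compound 2 to compound 3 (within the scatter), that is, no shift beyond the scatter. For compound 3 the estimated value in this assay is therefore 6000 nM, with a likely range from 2500 nM to 14000 nM.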

Compound 3, half-maximal inhibitory concentration: 4600 nM
For compound 3 the middle estimate is 1.3-fold (0.12 log units) above the measured one; low and high end bracket the measured number.
By their numbers in this assay, from the lowest: compounds 3, 1 and 2 (each within the scatter of the next).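

In this assay, putting fluoro in place of methyl on an aromatic carbon, next to the ring sulfur, gives a 1.3-fold lower number from compound 2 to compound 3 (0.12 log units; within the scatter) and so does not separate the two compounds. Within the data shown here, this is the first measured pair that differs in only one place, which makes it the first direct look at this position: here, a methyl group and a fluoro group, each counted as 1 heavy atom, cannot be told apart on this read-out. Nothing measured here explains the result, and the pair alone cannot show whether the position tolerates change in general or whether these two groups merely happen to give similar numbers.

Both groups at this position are small and carry no charge, so the compounds shown leave open what a larger or charged group would do there, such as an amine, a carboxylic acid or a longer chain. They also leave open whether the same exchange of methyl and fluoro would give a similar result elsewhere on the shared core.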